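The source may hold more compounds than are shown below. What is called first, only, known or untested is meant among the compounds shown, and "the series" means these compounds.

Values in a functional assay on MCF7 cells (Homo sapiens) for cytotoxicity, read by MTT assay, with a stated time of 24 h, tested at 16 ug/mL (on this read-out lower numbers stand for a weaker effect and higher numbers for a stronger effect at the one concentration tested), for the measured members of the series:

compound 1 `CN1CCN(CC(=O)Nc2ccc(-c3nc(-c4ccccc4)c(-c4ccccc4)n3C)cc2)CC1`: 30.1%
compound 2 `CCN1CCN(CC(=O)Nc2ccc(-c3nc(-c4ccccc4)c(-c4ccccc4)n3C)cc2)CC1`: 32.8%
compound 3 `Cn1c(-c2ccc(NC(=O)CN3CCN(Cc4ccccc4)CC3)cc2)nc(-c2ccccc2)c1-c1ccccc1`: 28.3%

Compound 3 carries the lowest of the three numbers, yet the difference is not meaningful: a number 1.8 percentage points lower from compound 1 to compound 3 (within the scatter) and a number 4.5 percentage points lower from compound 2 to compound 3 (within the scatter) are both within the scatter, as is a number 2.7 percentage points higher from compound 1 to compound 2 (within the scatter), so the three compounds read as one level.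

Compound 4 `Cc1ccc(CN2CCN(CC(=O)Nc3ccc(-c4nc(-c5ccccc5)c(-c5ccccc5)n4C)cc3)CC2)cc1` has not yet been measured. Going from compound 3 to compound 4 the change is methyl in place of hydrogen on an aromatic carbon. Within the data shown here, no measured step alters the aromatic ring itself; the three steps seen so far all exchange the group on the saturated chain carbon bound to the ring amine nitrogen, running from hydrogen through methyl to phenyl, and each stays within the scatter. The terminal end of the chain therefore appears tolerant of small edits at this concentration. A further small addition on that phenyl is expected to behave likewise, so a number 0.7 percentage points higher from compound 3 to compound 4 (within the scatter) is estimated to fall within the scatter. Compound 4 is expected to give 29%, in the range 20% to 39%.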

Compound 4, a percentage reported as activity, at one concentration (the size of the read-out at that concentration, not a potency): 26%
Compound 4: middle estimate off by 3 percentage points, on the high side; measured number inside the range.
By their numbers in this assay, from the lowest: compounds 4, 3, 1 and 2 (each within the scatter of the next).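

In this assay the first edit on the aromatic ring itself, a methyl on an aromatic carbon para to a large group, gives a number 2.3 percentage points lower from compound 3 to compound 4 (within the scatter) and so leaves 4-methylbenzyl at the same level as benzyl. The larger exchanges on the saturated chain carbon also stay at that level, with a number 6.8 percentage points lower from compound 2 to compound 4 (within the scatter) and a number 4.1 percentage points lower from compound 1 to compound 4 (within the scatter) as the printed steps, so the four compounds read as one level and the tolerance at the terminal end now extends to the outer phenyl ring. Nothing available explains this flat reading.

The compounds shown carry only a methyl on that phenyl ring, so a methoxy group, a chlorine, an amine or a carboxylic acid at this carbon remains open. Going by these compounds, with a single concentration, whether these compounds would show a stronger or weaker effect than one another at any other concentration also remains open.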